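Adding a Hydroxy Group to Compound 1

The compounds below may be only part of what the source reports. "The series", "measured", "known", "first", "only" and "open" are said of these compounds alone.

Of the compounds shown here, three have been measured in a functional assay on U-937 cells (Homo sapiens) for antiproliferative activity, read by WST assay, with a stated time of 48 h; on this read-out lower numbers stand for stronger inhibition and higher numbers for weaker inhibition. Compound 1 `COc1ccc([C@@H]2CCc3c(OC)cc(OC)cc3O2)cc1` gives 21000 nM, the lowest of the three numbers. Compound 3 `COc1cc(OC)c2c(c1)O[C@H](c1ccc(O)cc1)CC2` gives 40000 nM, and compound 2 `COc1cc(-c2coc3cc(O)cc(O)c3c2=O)ccc1O` gives 85000 nM. Going by the values given here, the only single-point step among them, a 1.9-fold higher number from compound 1 to compound 3 (0.28 log units; within the scatter), lies within the scatter. Compound 4 `COc1ccc([C@@H]2CCc3c(OC)cc(OC)cc3O2)c(O)c1` differs from compound 1 as follows: hydroxy in place of hydrogen on an aromatic carbon. Among the compounds with values here, no measured step adds a hydroxy group to the shared core, so the one step at hand bears on this change only loosely; it shows that a small change at an oxygen on an aromatic ring left the number in this assay essentially unmoved. Compound 4 is therefore expected to show a 1.2-fold higher number from compound 1 to compound 4 (0.08 log units; within the scatter), with no clear direction beyond the scatter. Compound 4 is estimated at 25000 nM, ranging from 10000 nM to 60000 nM.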

Compound 4, half-maximal inhibitory concentration: 4300 nM
Beside the measured number, compound 4's estimate is 5.8-fold (0.76 log units) above it, outside the stated range (below it).
By their numbers in this assay, from the lowest: compound 4; then compounds 1 and 3 (each within the scatter of the next); then compound 2.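

In this assay the hydroxy group, placed on an aromatic carbon ortho to a large group and meta to a methoxy group, gives a clear step (a 4.9-fold lower number from compound 1 to compound 4 (0.69 log units; beyond the scatter)) that lies beyond the scatter. Going by these compounds alone, the earlier step at an oxygen on an aromatic ring stayed within the scatter, so this carbon is the first place on the shared core where a single change moves the number clearly. Nothing at hand accounts for this step. The compounds shown leave open whether an amine or a fluorine atom on this carbon would give a similar step.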